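The source may hold more compounds than are shown below. What is called first, only, known or untested is meant among the compounds shown, and "the series" means these compounds.

Working notes on the series: in an ADME assay on the whole organism (Rattus norvegicus) for pharmacokinetics, at a dose of 10 mg/kg by the oral route (a lower number here means less compound in the circulation, a higher number more compound in the circulation at the dose given), compound 1 `C[C@@H](Oc1cc(C(=O)N(C)C)ccc1Nc1nc(O[C@H]2CC[C@@](C)(O)CC2)c2c(Cl)c[nH]c2n1)C(F)(F)F` gives 14500 ng.h/mL and compound 3 `COc1cc(C(=O)N(C)C)ccc1Nc1nc(O[C@H]2CCOC(C)(C)C2)c2cc[nH]c2n1` gives 13200 ng.h/mL, two values within the scatter of each other. Compound 2 `CCOc1cc(C(=O)N(C)C)ccc1Nc1nc(O[C@H]2CC[C@@](C)(O)CC2)c2cc[nH]c2n1` offers no comparison, since its entry reads "not determined" (no result reported). Within the data shown here, compound 3 therefore stands level with the only other number available, and it is the reference for the next reading.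

Compound 4 `COc1cc(N2CCN(C(=O)CO)CC2)ccc1Nc1nc(O[C@H]2CCOC(C)(C)C2)c2cc[nH]c2n1` departs from compound 3 at one place: 4-((hydroxymethyl)carbonyl)piperazin-1-yl in place of dimethylcarbamoyl on an aromatic carbon. In words, 4-((hydroxymethyl)carbonyl)piperazin-1-yl stands in place of dimethylcarbamoyl on an aromatic carbon, meta to a methoxy group. The entering group is the larger of the two and brings a six-membered non-aromatic ring.

Among the measured compounds shown here, no measured pair shows this change or any other single change, so the size of the step rests on judgement alone, and the uncertainty is wide. A fall in this assay beyond the scatter is expected, taken from compound 3 at 13200 ng.h/mL. The estimated change is a 3.3-fold lower number from compound 3 to compound 4 (0.52 log units; beyond the scatter). For compound 4 the estimated value is 4000 ng.h/mL, with an expected range of 1100 ng.h/mL to 12000 ng.h/mL.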

Compound 4, area under the concentration-time curve: 4850 ng.h/mL
Beside the measured number, compound 4's estimate is 1.2-fold (0.08 log units) below it, and the stated range covers the measured number.
By their numbers in this assay, from the lowest: compound 4; then compounds 3 and 1 (each within the scatter of the next).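

In this assay, among these compounds, the replacement of dimethylcarbamoyl on an aromatic carbon by 4-((hydroxymethyl)carbonyl)piperazin-1-yl gives a 2.7-fold lower number from compound 3 to compound 4 (0.43 log units; beyond the scatter) and is the first single change that can be read. This position, meta to a methoxy group and para to a large group, therefore does not leave the number untouched, although compound 4 still gives 4850 ng.h/mL with the larger group in place. The entering group differs in size, in its six-membered non-aromatic ring and in its hydrogen-bond donor all at once, this single step cannot separate these features, and nothing at hand bears on why the number falls.

The compounds shown leave open whether the piperazine ring with a plain acetyl or methyl on its far nitrogen would give a step of the same size, and how a morpholine amide or a carboxylic acid on this aromatic carbon would read. Also open, from the compounds shown here alone, is whether the same replacement would give a similar step on the rest of compound 1, which differs from compound 3 in more than one place.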